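Swapping methoxy for bromo on the shared core

The compounds below may be only part of what the source reports. "The series", "measured", "known", "first", "only" and "open" are said of these compounds alone.

Compound 1 `COc1ccc(C(=O)n2c(-c3cn(C)c4ccc(OC)cc34)nc3ccccc32)cc1`: 12800 nM
Compound 2 `COc1ccc2c(c1)c(-c1nc3ccccc3n1C(=O)c1ccccc1Br)cn2C`: 54200 nM
Compound 3 `COc1ccc2c(c1)c(-c1nc3ccccc3n1C(=O)c1cccc(Br)c1)cn2C`: 51300 nM

In a functional assay on HepG2 cells (Homo sapiens) for inhibition, read by MTT assay, with a stated time of 24 h (a higher number here means a weaker inhibitor of growth, a lower number a stronger inhibitor of growth), compound 3 gives 51300 nM. The closest measured comparison is a 1.1-fold lower number from compound 2 to compound 3 (0.02 log units; within the scatter), and the furthest is a 4.0-fold higher number from compound 1 to compound 3 (0.60 log units; beyond the scatter). Compound 4 `Cn1cc(-c2nc3ccccc3n2C(=O)c2cccc(Br)c2)c2cc(Br)ccc21` has bromo in place of methoxy on an aromatic carbon of the shared core: bromo in place of methoxy on an aromatic carbon. Within the data shown here, no measured step touches this place. The nearest guides are similar swaps on the group attached to the carbonyl carbon: a 4.2-fold higher number from compound 1 to compound 2 (0.63 log units; beyond the scatter) and a 4.0-fold higher number from compound 1 to compound 3 (0.60 log units; beyond the scatter), both modest rises. A smaller rise in this assay is therefore expected, possibly no larger than the scatter. The expected change is a 1.7-fold higher number from compound 3 to compound 4 (0.22 log units; within the scatter). For compound 4 the estimate is 85000 nM, with an expected range from 30000 nM to 200000 nM.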

Compound 4, concentration for 50% growth inhibition: 67300 nM
Beside the measured number, compound 4's estimate is 1.3-fold (0.10 log units) above it; measured number inside the range.
By their numbers in this assay, from the lowest: compound 1; then compounds 3, 2 and 4 (each within the scatter of the next).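

On this aromatic carbon of the shared core, bromo in place of methoxy gives a 1.3-fold higher number from compound 3 to compound 4 (0.12 log units; within the scatter) in this assay, so these two groups cannot be told apart here. By contrast, the swap on the carbonyl carbon gave a 4.0-fold higher number from compound 1 to compound 3 (0.60 log units; beyond the scatter), a step that the change on the core does not match. No measured evidence bears on this result.

From the compounds shown here alone, whether an amine or a carboxylic acid on this aromatic carbon would move the number beyond the scatter stays open. So does whether bromo here would act the same alongside the 4-methoxyphenyl group of compound 1.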